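Methyl for hydrogen on a shared ring

The source may report more compounds than this note shows. Statements on the series, on what has been measured and on what is new or still open speak of the compounds shown alone.

Compound 1 `CC(C)Oc1cc(Oc2ccc(S(C)(=O)=O)cc2)cc(-c2nccc(=O)[nH]2)c1` and compound 2 `Cc1cnc(-c2cc(Oc3ccc(S(C)(=O)=O)cc3)cc(OC(C)C)c2)[nH]c1=O` share one core; compound 3 `CC(C)Oc1cc(Oc2cnc(C(=O)N(C)C)nc2)cc(-c2nccc(=O)[nH]2)c1` and compound 4 `Cc1cnc(-c2cc(Oc3cnc(C(=O)N(C)C)nc3)cc(OC(C)C)c2)[nH]c1=O` share another. The difference between the two cores is not broken down here. In a physicochemical assay for lipophilicity, using the shake flask method (a lower number here means a more polar compound, a higher number a more lipophilic compound), compound 1 gives 2.14, compound 2 gives 2.68, and compound 3 gives 0.97. Compound 3 stands lowest of the three measured numbers in this assay, with compound 1 nearest and compound 2 furthest; both gaps are beyond the scatter. Compound 4 has not yet been measured in this assay.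

The change from compound 1 to compound 2 is methyl in place of hydrogen on an aromatic carbon, and it moved this assay by a number 0.54 log units higher from compound 1 to compound 2 (beyond the scatter). The change from compound 3 to compound 4 is methyl in place of hydrogen on an aromatic carbon, the same change on the same kind of place, with the place described in identical words for both pairs. For the measured compounds named here, only these two occurrences of the change appear among the compounds here, so the single measured step is the only guide to its size.

For compound 4 the step in this assay is expected to be a number 0.53 log units higher from compound 3 to compound 4 (beyond the scatter), because the same change gave a number 0.54 log units higher from compound 1 to compound 2 (beyond the scatter) on the other core. On that basis compound 4 is estimated at 1.5 in this assay, with a likely range from 1.2 to 1.8, before its measurement is known.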

Compound 4, distribution coefficient: 1.48
Compound 4: middle estimate off by 0.02 log units, on the high side; low and high end bracket the measured number.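

In this assay methyl in place of hydrogen on an aromatic carbon of the six-membered aromatic ring with 2 nitrogen gives a number 0.51 log units higher from compound 3 to compound 4 (beyond the scatter) and the same change on the other core gives a number 0.54 log units higher from compound 1 to compound 2 (beyond the scatter) so the step is close in size on both cores and carried over between them in this one matched comparison. This rests on two pairs only: it shows agreement on these two cores, not a general rule for the series, and it does not show that the step would keep its size on any further core. Nothing available here accounts for the size of the step or for its similarity on the two cores.

The compounds shown carry only hydrogen or methyl at this place, so it remains open how a longer chain such as ethyl, an amine or a carboxylic acid would read there on either core. Also open, on these data alone, is whether the methyl step holds its size on a third core, or with the methyl at another carbon of the same ring.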